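The source may report more compounds than this note shows. Statements on the series, on what has been measured and on what is new or still open speak of the compounds shown alone.

Compound 2 `O=C(/C=C/c1ccc2c(c1)B(O)OC2)c1ccc(I)cc1` carries an iodine on the aryl ketone side of the shared core, and in a functional assay on HCT-116 cells (Homo sapiens) for cytotoxicity, read by MTT assay, with a stated time of 48 h (a lower number here means a stronger inhibitor, a higher number a weaker inhibitor), compound 2 gives 11600 nM. Among the measured compounds shown here, of the two numbers measured so far this is the highest, yet its only neighbour, compound 1 `O=C(/C=C/c1ccc2c(c1)B(O)OC2)c1ccc(-c2ccccc2)cc1`, sits close by: in this assay compound 1 gives 9500 nM, and the step of a 1.2-fold higher number from compound 1 to compound 2 (0.09 log units; within the scatter) stays within the scatter. The change to compound 3 `O=C(/C=C/c1ccc2c(c1)B(O)OC2)c1cccc(O)c1` is 3-hydroxyphenyl in place of 4-iodophenyl on a carbonyl carbon. For the measured compounds named here, the one measured step, iodo in place of phenyl, touches the same aryl ring and was small, but no measured pair speaks to a hydroxyl group, so there is no direct guide. On that basis a step beyond the scatter is not expected, and the estimated step is a 1.0-fold higher number from compound 2 to compound 3 (0.01 log units; within the scatter). Compound 3 is therefore expected to give about 12000 nM in this assay, in a range from 5000 nM to 30000 nM.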

Compound 3, half-maximal inhibitory concentration: 6500 nM
Beside the measured number, compound 3's estimate is 1.8-fold (0.27 log units) above it; measured number inside the range.
By their numbers in this assay, from the lowest: compounds 3, 1 and 2 (each within the scatter of the next).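

In this assay, exchanging 4-iodophenyl for 3-hydroxyphenyl on a carbonyl carbon stays within the scatter (a 1.8-fold lower number from compound 2 to compound 3 (0.25 log units; within the scatter)). The earlier step changed only what the aryl ring carried, whereas this one replaces the whole aryl group, removes the iodine, and brings in 1 hydrogen-bond donor and 1 hydrogen-bond acceptor, and the number still does not move beyond the scatter, so at this position the three aryl groups shown cannot be told apart in this measurement. Nothing given here explains this result.

The compounds shown leave open whether an amine or a carboxylic acid on this aryl ring would produce a step beyond the scatter. They also leave open how a change to the shared core itself, rather than to this aryl group, would read.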